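Cytotoxicity notes on an aminooxazole series

This account rests on a few compounds, and the source may have more. Where it says the series, first, only, none or still open, it means among the compounds named here.

Measured so far:
compound 1, `Fc1cccc(F)c1Cc1cnc(Nc2ccc(-c3ccncc3)c(Cl)c2)o1`, 9300 nM
compound 2, `CSCc1ccc(Nc2ncc(Cc3c(F)cccc3F)o2)cc1`, > 100000 nM
compound 3, `Clc1cccc(Cl)c1Cc1nnc(Nc2ccc(COCc3ccccc3)cc2)o1`, 84000 nM

Of the compounds shown here, three have been read in an ADME assay on MT2 cells (Homo sapiens) for cytotoxicity, read by MTT assay; a higher number here means that more compound is tolerated, a lower number that less compound is tolerated. Compound 1 gives 9300 nM, and compound 3 gives 84000 nM. Compound 2 is different: its value of > 100000 nM is a limit of this assay and not a number, so it is only known that compound 2 is tolerated up to that limit. This is the limit of > 100000 nM in this assay, at which 1 of the 3 values shown sits, and it places compound 2 at the tolerated end of the three values shown.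

The next compound, compound 4, `O=c1ncccn1SCCc1ccc(Nc2ncc(Cc3c(F)cccc3F)o2)cc1`, is to be read in this assay. It differs from compound 2 in one place: a group of 9 heavy atoms (5 carbon, 2 nitrogen, 1 oxygen, 1 sulfur; one six-membered aromatic ring with 2 hetero atoms) in place of a group of 2 heavy atoms (1 carbon, 1 sulfur; no ring), on a saturated chain carbon bound to an aromatic carbon.

Going by the values given here, no step between measured compounds is available that would show what such a change does in this assay. Since compound 2 sits at a limit, only a downward step or none at all can be seen from here. A moderate drop in tolerated concentration is expected, an at least 1.6-fold lower number from compound 2 to compound 4 (0.22 log units; that floor lies within the scatter), though a value still at the limit would not be surprising. For compound 4 the estimate in this assay is 60000 nM, with a range from 15000 nM to 100000 nM.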

Compound 4, half-maximal cytotoxic concentration: > 100000 nM
Compound 4 was reported as a limit; the forecaster's own chance of this, stated with the estimate: 40%; at least 1.6-fold (0.22 log units) between middle value and limit.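

Compound 4 gives > 100000 nM in this assay, a limit and not a number. Compound 2 stands at the same limit, so no step from compound 2 to compound 4 can be read: the limit of > 100000 nM in this assay, at which 2 of the 4 values shown sit.

The compounds shown leave open what the exchange of methylsulfanyl for the larger ring-bearing group does in this assay.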